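Methoxycarbonyl for Ethyl on a Trifluoroethoxy Pyrrolinone Core

The source may hold more compounds than are shown below. What is called first, only, known or untested is meant among the compounds shown, and "the series" means these compounds.

Three compounds sharing one core were tested in a functional assay on HeLa cells (Homo sapiens) for inhibition; on this read-out lower numbers stand for stronger inhibition and higher numbers for weaker inhibition. Compound 1, `CCc1ccc(N2C(=O)C=CC2OCC(F)(F)F)cc1`, gives 6510 nM in this assay, which is the second highest of the three numbers. Compound 2, `O=C1C=CC(OCC(F)(F)F)N1c1ccc(Cl)cc1F`, gives 8320 nM, and the two values lie within the scatter of each other, so nothing separates them. Compound 3, `O=C1C=CC(OCC(F)(F)F)N1c1ccc(F)c(Cl)c1`, gives 3110 nM, the lowest of the three and beyond the scatter from compound 1. No two of these compounds differ in a single place, so no step between measured compounds can be read off.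

The next compound, compound 4, `COC(=O)c1ccc(N2C(=O)C=CC2OCC(F)(F)F)cc1`, differs from compound 1 in one place: methoxycarbonyl in place of ethyl on an aromatic carbon. Ethyl leaves and methoxycarbonyl enters on an aromatic carbon of the six-membered carbon ring, para to a large group.

Among the compounds with values here, no measured pair shows what such an exchange does here, so the expectation rests on the narrow spread of the three numbers, all of which sit in the same region. For compound 4 a step from compound 1 of a 1.1-fold higher number from compound 1 to compound 4 (0.03 log units; within the scatter) is expected, that is, little movement beyond the scatter in either direction. The value of compound 4 in this assay is therefore estimated at 7000 nM, with a range from 2500 nM to 20000 nM.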

Compound 4, half-maximal inhibitory concentration: 5700 nM
Estimate against measurement, compound 4: 1.2-fold (0.09 log units) above; the range from low to high includes it.
By their numbers in this assay, from the lowest: compounds 3, 4, 1 and 2 (each within the scatter of the next, the first and the last beyond it).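

In this assay, within the data shown here, the exchange of ethyl for methoxycarbonyl provides the first single-place step on the shared core, a 1.1-fold lower number from compound 1 to compound 4 (0.06 log units; within the scatter), and this step lies within the scatter. At this aromatic carbon, para to a large group, the read-out therefore does not separate the two groups, even though methoxycarbonyl has more heavy atoms than ethyl, contains oxygen, and brings hydrogen-bond acceptors that ethyl lacks, so this one exchange shows that such differences in composition need not move the number beyond the scatter. No accompanying measurement offers an explanation for this result.

A single exchange cannot show whether the position is generally insensitive, and a carboxylic acid, a primary amine, a longer alkyl chain or plain hydrogen on the same carbon could still move the number beyond the scatter. From the compounds shown here alone, it also remains open whether methoxycarbonyl would give a similarly small step on a ring that also carries chlorine and fluorine, as the rings of compound 2 and compound 3 do.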